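A Second Methoxy Group on the Side Ring of Compound 1

The source may report more compounds than this note shows. Statements on the series, on what has been measured and on what is new or still open speak of the compounds shown alone.

Three compounds sharing one core were tested in a functional assay on KB cells (Homo sapiens) for antiproliferative activity, read by sulforhodamine B assay, with a stated time of 3 days; on this read-out higher numbers stand for an effect only at larger amounts of compound and lower numbers for an effect already at smaller amounts. Compound 1 `CCC1=C(O)c2c(oc(-c3ccccc3OC)cc2=O)C(CC)(CC)C1=O` gives 40.8 uM. Compound 2 `CCC1=C(O)c2c(oc(-c3cc(C)c(OC)cc3C)cc2=O)C(CC)(CC)C1=O` gives 36.6 uM, and compound 3 `CCC1=C(O)c2c(oc(-c3cc(C)ccc3C)cc2=O)C(CC)(CC)C1=O` gives 14.5 uM. Compound 1 differs from compound 3 in the group attached to the core: 2-methoxyphenyl in place of 2,5-dimethylphenyl on an aromatic carbon. This exchange gives a 2.8-fold lower number from compound 1 to compound 3 (0.45 log units; beyond the scatter). Compound 2 arises from compound 3 by one added group: methoxy in place of hydrogen on an aromatic carbon. That addition gives a 2.5-fold higher number from compound 3 to compound 2 (0.40 log units; beyond the scatter). Compound 4 `CCC1=C(O)c2c(oc(-c3cc(OC)ccc3OC)cc2=O)C(CC)(CC)C1=O`, not yet measured, arises from compound 1 by the same kind of change: methoxy in place of hydrogen on an aromatic carbon. The surroundings differ, though: in compound 2 the new group sits ortho to a methyl group, meta to a methyl group and para to a large group, whereas in compound 4 it sits meta to a large group and para to a methoxy group. Because the earlier addition gave a 2.5-fold higher number from compound 3 to compound 2 (0.40 log units; beyond the scatter), a step of similar direction is expected, with the size left uncertain by the different surroundings: the step is estimated at a 1.5-fold higher number from compound 1 to compound 4 (0.17 log units; within the scatter). Compound 4 is therefore expected to give about 60 uM in this assay, estimated to fall between 30 uM and 120 uM.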

Compound 4, concentration for half-maximal effect: 8.8 uM
Compound 4: middle estimate off by 6.8-fold (0.83 log units), on the high side; measured number outside the range, below it.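

In this assay, putting methoxy in place of hydrogen on an aromatic carbon gives a 4.6-fold lower number from compound 1 to compound 4 (0.67 log units; beyond the scatter), so this change moved the number in opposite directions on the two cores and cannot be carried from one to the other as a fixed step: the same change on two cores in this assay, a 2.5-fold higher number (0.40 log units; beyond the scatter) from compound 3 to compound 2 and a 4.6-fold lower number (0.67 log units; beyond the scatter) from compound 1 to compound 4, 12-fold (1.07 log units) apart, beyond the scatter of two such steps

What this does not show is the reason, as the comparison rests on just two steps. In compound 4 the new group sits meta to a large group and para to a methoxy group, and the effect of these surroundings cannot be separated here from the other differences between the two side rings.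

The compounds shown leave open whether methoxy placed elsewhere on the side ring of compound 1 would also lower the number. They also leave open whether a hydroxy group, a fluorine atom or a longer chain such as ethoxy, set where the new methoxy stands in compound 4, would change the number in the same direction.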